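A few compounds are considered here, and "the series" means these few. Any claim that something is new, unique, unknown or untested is made for them only; others in the source may bear on it.

Measured compounds:
Compound 1, `Cc1cc(Nc2cc(-c3ccccc3)[nH]n2)n2nc(SCc3c(Cl)cccc3Cl)nc2n1`, in a functional assay on MGC-803 cells (Homo sapiens) for inhibition, read by MTT assay, with a stated time of 72 h (a lower number here means a stronger inhibitor, a higher number a weaker inhibitor), gives 5280 nM.
Compound 2, `Cc1cc(Nc2cc(-c3ccccc3)[nH]n2)n2nc(SCc3ccc(Cl)cc3)nc2n1`, gives 3950 nM.
Compound 3, `Cc1cc(Nc2cc(-c3ccccc3)[nH]n2)n2nc(SCc3ccc(C(F)(F)F)cc3)nc2n1`, gives 3520 nM.

Compound 2 holds the second highest of these three numbers; its nearest neighbour is compound 3, a 1.1-fold lower number from compound 2 to compound 3 (0.05 log units; within the scatter), and its furthest is compound 1, a 1.3-fold lower number from compound 1 to compound 2 (0.13 log units; within the scatter). Compound 4, `Cc1nc2nc(SCc3ccc(Cl)cc3)nn2c(Nc2cc(-c3ccccc3)[nH]n2)c1C`, differs from compound 2 in one place: methyl in place of hydrogen on an aromatic carbon. Among the compounds with values here, no measured step touches this place; all three steps changed the group on the saturated chain carbon bound to a sulfur, and each stayed within the scatter (a 1.5-fold lower number from compound 1 to compound 3 (0.18 log units; within the scatter) as well). The change to compound 4 therefore has no direct guide, and no step beyond the scatter is expected, a 1.0-fold lower number from compound 2 to compound 4 (0.01 log units; within the scatter). Compound 4 is estimated at 3900 nM, between 1500 nM and 10000 nM.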

Compound 4, half-maximal inhibitory concentration: 9050 nM
Estimate against measurement, compound 4: 2.3-fold (0.37 log units) below, within the range that was stated.
By their numbers in this assay, from the lowest: compounds 3, 2, 1 and 4 (each within the scatter of the next, the first and the last beyond it).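

In this assay a single added methyl, only one heavy atom, on the aromatic carbon of the six-membered ring gives a 2.3-fold higher number from compound 2 to compound 4 (0.36 log units; beyond the scatter) and so a weaker inhibitor. The earlier changes, all on the group carried by the chain carbon bound to sulfur, stayed within the scatter, so this ring carbon is the first place shown where a change exceeds it. Nothing shown explains this loss.

With only hydrogen and methyl shown here, an amine, a methoxy group or a longer chain such as ethyl remains open. So does whether methyl costs as much alongside the other groups on the chain carbon.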